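The compounds below may be only part of what the source reports. "The series", "measured", "known", "first", "only" and "open" are said of these compounds alone.

Measured so far:
Compound 1 `COc1cc(-c2nc(N(C)C)sc2-c2ccc3ccccc3c2)cc(OC)c1OC`: 1400 nM
Compound 2 `COc1ccc(-c2sc(N(C)C)nc2-c2cc(OC)c(OC)c(OC)c2)cc1`: 3370 nM

In a functional assay on HeLa cells (Homo sapiens) for antiproliferative activity, read by MTT assay, with a stated time of 72 h (a higher number here means a weaker inhibitor, a lower number a stronger inhibitor), compound 2 stands highest of the two numbers, the weaker inhibitor; the nearest is compound 1, separated by a 2.4-fold higher number from compound 1 to compound 2 (0.38 log units; beyond the scatter). Compound 3 `COc1ccc(-c2sc(C)nc2-c2cc(OC)c(OC)c(OC)c2)cc1` differs from compound 2 by methyl in place of dimethylamino on an aromatic carbon. Going by the values given here, no measured step touches this position: the single recorded step concerns the aryl group and gives no direct guide. A change within or just beyond the scatter is expected, direction uncertain. The estimated step is a 1.3-fold higher number from compound 2 to compound 3 (0.13 log units; within the scatter). For compound 3 in this assay the expected value is 4500 nM, in the range 1500 nM to 14000 nM.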

Compound 3, half-maximal inhibitory concentration: 500 nM
Estimate against measurement, compound 3: 9.0-fold (0.95 log units) above; measured number outside the range, below it.
By their numbers in this assay, from the lowest: compound 3; then compound 1; then compound 2.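

In this assay this position is not neutral: methyl in place of dimethylamino, on the aromatic carbon next to the ring nitrogen and next to the ring sulfur, gives a 6.7-fold lower number from compound 2 to compound 3 (0.83 log units; beyond the scatter) and makes compound 3 the lowest number of the three. Going by these compounds alone, the earlier step spoke only to the aryl group, so this is the first reading at this carbon. Nothing available explains the step.

Going by these compounds, whether a primary amine, an ethyl chain or a carboxylic acid here would follow methyl or dimethylamino stays open. So does whether methyl gives a similar step alongside naphthalen-2-yl.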